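Amide aryl variation and an expected value for compound 4

The compounds below may be only part of what the source reports. "The series", "measured", "known", "first", "only" and "open" are said of these compounds alone.

compound 1: `O=C(Nc1cccc(-c2oc3cc(-c4ccc(F)cc4)ccc3c(=O)c2O)c1)c1ccc(F)cc1F`; in a functional assay on HCC1937 cells (Homo sapiens) for antiproliferative activity, read by CCK-8 assay, with a stated time of 72 h (a higher number here means a weaker inhibitor, a lower number a stronger inhibitor), compound 1 gives 6980 nM
compound 2: `O=C(Nc1cccc(-c2oc3cc(-c4ccc(F)cc4)ccc3c(=O)c2O)c1)c1ccc(Br)cc1`; in this assay compound 2 gives 8630 nM
compound 3: `CCc1ccc(C(=O)Nc2cccc(-c3oc4cc(-c5ccc(F)cc5)ccc4c(=O)c3O)c2)cc1`; in this assay compound 3 gives 13200 nM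

Compound 3 holds the highest of the three numbers, but it is not separated from the others: a 1.9-fold higher number from compound 1 to compound 3 (0.28 log units; within the scatter) and a 1.5-fold higher number from compound 2 to compound 3 (0.18 log units; within the scatter) both lie within the scatter, as does a 1.2-fold higher number from compound 1 to compound 2 (0.09 log units; within the scatter). On these numbers the three aryl groups on the carbonyl carbon cannot be told apart.

Compound 4, `COc1ccc(C(=O)Nc2cccc(-c3oc4cc(-c5ccc(F)cc5)ccc4c(=O)c3O)c2)c(F)c1`, is not yet measured. It differs from compound 3 in one place: 2-fluoro-4-methoxyphenyl in place of 4-ethylphenyl on a carbonyl carbon. For the measured compounds named here, the steps that bear on this change are the two that exchange the aryl group on the carbonyl carbon, a 1.9-fold higher number from compound 1 to compound 3 (0.28 log units; within the scatter) and a 1.2-fold higher number from compound 1 to compound 2 (0.09 log units; within the scatter), and neither goes beyond the scatter. Going by the values given here, compound 1 carries 2,4-difluorophenyl, which shares a fluorine with the 2-fluoro-4-methoxyphenyl of compound 4, and no measured step involves a methoxy-bearing aryl group. In this assay no step beyond the scatter is therefore expected, with a slight lean toward a lower number than compound 3 because a 1.9-fold higher number from compound 1 to compound 3 (0.28 log units; within the scatter) went the other way. Compound 4 is expected to give 9500 nM, within a range from 4000 nM to 22000 nM. This estimate corresponds to an expected 1.4-fold lower number from compound 3 to compound 4 (0.14 log units; within the scatter).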

Compound 4, half-maximal inhibitory concentration: 24500 nM
For compound 4 the middle estimate is 2.6-fold (0.41 log units) below the measured one; measured number outside the range, above it.
By their numbers in this assay, from the lowest: compounds 1, 2, 3 and 4 (each within the scatter of the next, the first and the last beyond it).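

In this assay, for the compounds shown here, the aryl group on the carbonyl carbon, which had not separated any of the earlier compounds, now gives two modest steps beyond the scatter: one for methoxy in place of fluoro on an aromatic carbon (a 3.5-fold higher number from compound 1 to compound 4 (0.55 log units; beyond the scatter)) and one for 2-fluoro-4-methoxyphenyl in place of 4-bromophenyl (a 2.8-fold higher number from compound 2 to compound 4 (0.45 log units; beyond the scatter)). The change from 4-ethylphenyl to 2-fluoro-4-methoxyphenyl stays within the scatter (a 1.9-fold higher number from compound 3 to compound 4 (0.27 log units; within the scatter)), so this position responds to some aryl exchanges but not to all of them, and compound 3 cannot be told apart from compound 4. Nothing available here accounts for these steps.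

The compounds shown hold no aryl group carrying methoxy without the fluorine, so the parts played by the two substituents of 2-fluoro-4-methoxyphenyl remain unseparated. On these data alone, it also remains open whether a hydroxy group, a dimethylamino group or a longer ethoxy chain on that aromatic carbon would give a higher or lower number than methoxy, and the shared core and the amide stay the same throughout.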